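The source may hold more compounds than are shown below. What is called first, only, known or untested is meant among the compounds shown, and "the series" means these compounds.

Measured compounds:
compound 1, `CC(C)(N)C(=O)N[C@H](COCc1ccccc1)c1nnnn1CCCCC#N` — in an assay on isolated protein for displacement of a labelled ligand from growth hormone secretagogue receptor type 1 (Homo sapiens), with a stated time of 1 h (on this read-out lower numbers stand for stronger inhibition and higher numbers for weaker inhibition), compound 1 gives 3120 nM
compound 2, `CC(C)(N)C(=O)N[C@H](COCc1ccccc1)c1nnn(Cc2ccc(NS(C)(=O)=O)cc2)n1` — in this assay compound 2 gives only a limit, > 5000 nM

Compound 2 stands at the edge of what this assay reports: its entry is the limit of > 5000 nM in this assay, at which 1 of the 2 values shown sits, so no number is known for it, and its distance from compound 1 cannot be stated. Compound 3, `CC(C)(N)C(=O)N[C@H](COCc1ccccc1)c1nnn(Cc2ccccc2NS(C)(=O)=O)n1`, is built from the same atoms and differs from compound 2 by 2-(methanesulfonamido)phenyl in place of 4-(methanesulfonamido)phenyl on a saturated chain carbon bound to an aromatic nitrogen. Among the compounds with values here, no step between two measured compounds exists in this set, so the size of such a rearrangement in this assay is not anchored by any observation. Within the data shown here, nothing among the measured compounds argues for a gain beyond the scatter, and the step from compound 2 to compound 3 is expected to be small, a step that the limit leaves unreadable from compound 2 to compound 3, with no clear direction. Compound 3 is therefore expected near 6000 nM, within 1500 nM to 20000 nM, and a limit rather than a number is the likelier outcome.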

Compound 3, inhibition constant: > 5000 nM
Compound 3: no number, only a limit (the forecaster's own chance of this, stated with the estimate: 60%); the middle value is on the limit's open side.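

In this assay, within the data shown here, compound 2 and compound 3 each give only a limit, so no step between them can be read: the limit of > 5000 nM in this assay, at which 2 of the 3 values shown sit. Left open is whether 2-(methanesulfonamido)phenyl and 4-(methanesulfonamido)phenyl differ at all on this read-out.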